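Amide Variation in a Weakly Growth-Inhibiting Acrylamide Series

The source may hold more compounds than are shown below. What is called first, only, known or untested is meant among the compounds shown, and "the series" means these compounds.

Measured so far:
Compound 1 `COC1CN(C(=O)/C=C/c2ccncc2-c2ccc3ccccc3c2)C1` — > 10000 nM (a limit of the assay, not a number)
Compound 2 `CNC(=O)/C=C/c1ccncc1-c1ccc2cc[nH]c2c1` — 9230 nM

Of the compounds shown here, two have been tested in a functional assay on MCF7 cells (Homo sapiens) for inhibition, read by sulforhodamine B assay, with a stated time of 72 h; on this read-out lower numbers stand for stronger inhibition of growth and higher numbers for weaker inhibition of growth. Compound 1 `COC1CN(C(=O)/C=C/c2ccncc2-c2ccc3ccccc3c2)C1` returns only a limit in this assay, > 10000 nM, so its position is known no further than that it sits at the limit of > 10000 nM in this assay, at which 1 of the 2 values shown sits. Compound 2 `CNC(=O)/C=C/c1ccncc1-c1ccc2cc[nH]c2c1` gives 9230 nM in this assay. Among the measured compounds shown here, the two compounds differ in more than one place, so no single step between measured compounds is available, and the two values can only be read side by side.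

Compound 3 `CN(C)C(=O)/C=C/c1ccncc1-c1ccc2ccccc2c1` is not yet measured. It differs from compound 1 in one place: dimethylamino in place of 3-methoxyazetidin-1-yl on a carbonyl carbon. Nothing measured here sets the size of such a change. The expected step is a number no higher from compound 1 to compound 3 (the limit leaves the size open), no larger than the usual scatter and in no settled direction. Compound 3 is therefore expected to give 10000 nM in this assay, with a range from 4000 nM to 30000 nM.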

Compound 3, concentration for 50% growth inhibition: 8190 nM
For compound 3 the middle estimate is 1.2-fold (0.09 log units) above the measured one; measured number inside the range.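

In this assay compound 1 gives > 10000 nM, which is a limit of the assay and not a number. Compound 3 gives 8190 nM, so this position on the core of compound 1 now has a number inside the range of the assay. Dimethylamino in place of 3-methoxyazetidin-1-yl on a carbonyl carbon can be read only as an at least 1.2-fold lower number from compound 1 to compound 3 (0.08 log units; that floor lies within the scatter), and the full size of the change stays open since one end of the step is a limit: the limit of > 10000 nM in this assay, at which 1 of the 3 values shown sits.

The compounds shown leave open whether a pyrrolidine, a morpholine or a longer chain such as diethylamino on this carbonyl carbon would give a number apart from that of compound 3. They also leave open how an azetidine without its methoxy group would read on the same core.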